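The compounds below may be only part of what the source reports. "The series", "measured", "known", "first", "only" and "open" are said of these compounds alone.

Compound 1 `Clc1ccc(/C=C/c2nnc(-c3ccc4c(c3)OCCO4)o2)cc1`: 8030 nM
Compound 2 `COc1cccc(/C=C/c2nnc(-c3ccc4c(c3)OCCO4)o2)c1`: > 50000 nM, a limit and not a number

In a functional assay on HUVEC cells (Homo sapiens) for antiproliferative activity, read by MTT assay, with a stated time of 48 h (on this read-out higher numbers stand for weaker inhibition and lower numbers for stronger inhibition), compound 2 stands at the limit of > 50000 nM in this assay, at which 1 of the 2 values shown sits. Compound 3 `C(=C/c1nnc(-c2ccc3c(c2)OCCO3)o1)\c1ccccc1` has hydrogen in place of methoxy on an aromatic carbon, leaving an unsubstituted phenyl. Among the compounds with values here, only one measured step bears on this: an at least 6.2-fold higher number from compound 1 to compound 2 (0.79 log units; beyond the scatter). That step lies beyond the scatter, but it swaps 4-chlorophenyl for 3-methoxyphenyl, so it is only a loose guide. Losing the methoxy is expected to bring the number down, partway towards compound 1 at 8030 nM. The expected change is an at least 2.5-fold lower number from compound 2 to compound 3 (0.39 log units; beyond the scatter). Compound 3 is estimated at 20000 nM, with an expected range of 6000 nM to 60000 nM.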

Compound 3, half-maximal inhibitory concentration: > 50000 nM
Compound 3: only a limit was reported; the forecaster's own chance of this, stated with the estimate: 40%; at least 2.5-fold (0.39 log units) between middle value and limit.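

In this assay compound 3 gives > 50000 nM, a limit and not a number, and compound 2 stands at the same limit: the limit of > 50000 nM in this assay, at which 2 of the 3 values shown sit. The step between these two cannot be read, so removing the methoxy brings no measurable activity into view. Hydrogen in place of chloro gives an at least 6.2-fold higher number from compound 1 to compound 3 (0.79 log units; beyond the scatter), leaving the 4-chlorophenyl as the only one of the three groups shown that gives an actual number.

Going by these compounds, whether chloro is special remains open, as another group in its place, such as fluoro, methyl or an amine, might also give a number.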